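The source may report more compounds than this note shows. Statements on the series, on what has been measured and on what is new or still open speak of the compounds shown alone.

Measured compounds:
Compound 1 `CCn1c(-c2ccc(C(F)(F)F)nc2)nc2c(O[C@H]3CCN(C(=O)C4CCOC4)C3)ncnc21`: 27 10^-6 cm/s
Compound 2 `CCC(=O)N1CC[C@H](Oc2ncnc3c2nc(-c2cnc(C)nc2)n3CC)C1`: 21 10^-6 cm/s
Compound 3 `CCC(=O)N1CC[C@H](Nc2ncnc3c2nc(-c2cnc(C)nc2)n3CC)C1`: 21 10^-6 cm/s

All three were tested in an ADME assay on LLC-PK1 cells (Sus scrofa) for permeability; a lower number here means that the compound crosses the layer more slowly, a higher number that the compound crosses the layer faster. Compound 1 gives 27 10^-6 cm/s there; the values of compound 2 and compound 3 lie within the usual scatter of that number, so the three compounds cannot be told apart on this assay. Compound 4 `CCn1c(-c2ccc(C(F)(F)F)nc2)nc2c(O[C@H]3CCN(C(=O)c4cocn4)C3)ncnc21` has not been measured yet. It differs from compound 1 in one place: 1,3-oxazol-4-yl in place of oxolan-3-yl on a carbonyl carbon. Among the measured compounds shown here, no pair of measured compounds shows a comparable change, so there is no step to lean on. For the measured compounds named here, with no such step available, the expectation for compound 4 is a result close to that of compound 1, with no step beyond the scatter, written as a 1.2-fold lower number from compound 1 to compound 4 (0.09 log units; within the scatter). Compound 4 is therefore estimated at 22 10^-6 cm/s, with a range from 12 10^-6 cm/s to 40 10^-6 cm/s.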

Compound 4, apparent permeability: 29 10^-6 cm/s
Beside the measured number, compound 4's estimate is 1.3-fold (0.12 log units) below it; low and high end bracket the measured number.
By their numbers in this assay, from the lowest: compounds 2, 3, 1 and 4 (each within the scatter of the next).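

In this assay, placing 1,3-oxazol-4-yl instead of oxolan-3-yl on the carbonyl carbon gives a 1.1-fold higher number from compound 1 to compound 4 (0.03 log units; within the scatter). Among the compounds shown here, this is the first measured change at this position, and it shows that a five-membered aromatic ring and a five-membered non-aromatic ring cannot be told apart here, at least in this pair. No supporting measurement offers an explanation for this result. One pair cannot show how far this tolerance extends. From the compounds shown here alone, whether an amine or a carboxylic acid on the same carbonyl carbon would also leave the number within the scatter remains open.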